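A Bromo-to-Methyl Swap on the Shared Core

The source may report more compounds than this note shows. Statements on the series, on what has been measured and on what is new or still open speak of the compounds shown alone.

Compound 1 (`C=C1C[C@]23C[C@@]1(O)CC[C@@H]2c1cccc(C)c1[C@@H]3Cn1cc(-c2ccc(Br)cc2)nn1`) was tested in a functional assay on SMMC-7721 cells (Homo sapiens) for cytotoxicity, read by MTT assay, with a stated time of 4 days; on this read-out higher numbers stand for weaker inhibition and lower numbers for stronger inhibition. In this assay compound 1 gives > 20000 nM, and that figure is a limit of the assay rather than a measured number. Compound 2 (`C=C1C[C@]23C[C@@]1(O)CC[C@H]2c1ccc(O)c(C)c1[C@@H]3Cn1cc(-c2ccccc2)nn1`) also gives > 20000 nM in this assay, again a limit. The third measured compound, compound 3 (`C=C1C(=O)[C@]23C[C@@]1(O)CC[C@H]2c1ccc(OS(=O)(=O)c2ccc(C)cc2)c(C)c1[C@@H]3Cn1cc(-c2ccc(F)cc2)nn1`), gives 4280 nM in this assay, a true number. (the limit of > 20000 nM in this assay, at which 2 of the 3 values shown sit), so compound 1 stands at the weak end of what has been seen.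

Compound 4 (`C=C1C[C@]23C[C@@]1(O)CC[C@@H]2c1cccc(C)c1[C@@H]3Cn1cc(-c2ccc(C)cc2)nn1`) differs from compound 1 in one spot: methyl in place of bromo on an aromatic carbon. Among the compounds with values here, no pair of measured compounds shows this same change, so no measured step says how large its effect should be. With nothing to push the number in either direction, the step of a number no higher from compound 1 to compound 4 (the limit leaves the size open) is expected to stay within the scatter, that is, no real change. Compound 4 is therefore expected to give about 20000 nM, within a range from 8000 nM to 50000 nM, and quite possibly again only a limit.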

Compound 4, half-maximal inhibitory concentration: > 20000 nM
Compound 4: no number, only a limit; the forecaster's own chance of this, stated with the estimate: 75%; the middle value sits exactly at the limit.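

Compound 1 and compound 4 both give only a limit in this assay, so no step can be read for methyl in place of bromo. The compounds shown leave open whether this swap changes cytotoxicity at all, as most values stop at the same limit: the limit of > 20000 nM in this assay, at which 3 of the 4 values shown sit.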